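A few compounds are considered here, and "the series" means these few. Any claim that something is new, unique, unknown or untested is made for them only; others in the source may bear on it.

Measured compounds

Compound 1: `Cc1ccc(C(F)(F)F)cc1COc1cc(NC(=O)c2ccc(Br)cc2)ccc1N(C)S(C)(=O)=O`, 9490 nM
Compound 2: `COc1ccc(C(=O)Nc2ccc(N(C)S(C)(=O)=O)c(OCc3cc(C(F)(F)F)ccc3C)c2)cc1`, 2030 nM
Compound 3: `COc1ccc(OC)c(COc2cc(NC(=O)c3ccc(Br)cc3)ccc2N(C)S(=O)(=O)C(F)(F)F)c1`, 470 nM

All three values come from a functional assay on SK-BR-3 cells (Homo sapiens) for antiproliferative activity, read by MTT assay, with a stated time of 48 h; on this read-out lower numbers stand for stronger inhibition and higher numbers for weaker inhibition. Compound 1 gives 9490 nM and compound 2 gives 2030 nM; the two share a core and differ only by methoxy in place of bromo on an aromatic carbon, and this step reads a 4.7-fold lower number from compound 1 to compound 2 (0.67 log units; beyond the scatter). Compound 3 gives 470 nM, the lowest number among the three measured compounds, and its steps to compound 2 and to compound 1 are both beyond the scatter. The difference between the core of compound 3 and the core of compound 1 is not broken down here.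

Compound 4, `COc1ccc(C(=O)Nc2ccc(N(C)S(=O)(=O)C(F)(F)F)c(OCc3cc(OC)ccc3OC)c2)cc1`, has not yet been measured. It differs from compound 3 by methoxy in place of bromo on an aromatic carbon, on the core of compound 3. This is the same change that separates compound 1 from compound 2: the group that leaves, the group that enters and the place all read the same word for word. Within the data shown here, the expectation is therefore that compound 4 follows compound 3 with a step of about the same size as the one from compound 1 to compound 2, with the caveat that the change has been seen only once and on a different core, so the step could be smaller or larger than that single case. On this basis the expected step is a 4.3-fold lower number from compound 3 to compound 4 (0.63 log units; beyond the scatter). Compound 4 is estimated at 110 nM, with a range of 40 nM to 320 nM.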

Compound 4, half-maximal inhibitory concentration: 110 nM
Compound 4: middle estimate and measured number agree at the digits printed, and the stated range covers the measured number.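

In this assay, methoxy in place of bromo on an aromatic carbon, para to a large group, gives a 4.3-fold lower number from compound 3 to compound 4 (0.63 log units; beyond the scatter), so the change also lowers the number on the core of compound 3. Set beside the same change on the core of compound 1, the size of the step carries over from one core to the other, and the gap between the two steps gives no sign that the core alters it: the same change on two cores in this assay, a 4.7-fold lower number (0.67 log units; beyond the scatter) from compound 1 to compound 2 and a 4.3-fold lower number (0.63 log units; beyond the scatter) from compound 3 to compound 4, 1.1-fold (0.04 log units) apart, within the scatter of two such steps

This agreement rests on a single pair of cores, a single place on the molecule and a single cell assay, so it is no general rule for the series, and it gives no reason for the lower number with methoxy or for the lower numbers on the core of compound 3.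

The compounds shown leave open how an amine, a carboxylic acid or a longer alkoxy chain would read in place of methoxy on that aromatic carbon, and whether the step would keep its size there. Also open, going by these compounds, is which part of the difference between the two cores sets the level of each pair, and whether the step would hold on a core that departs further from these two.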